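Ethoxy to methoxy on the acid-bearing core: expected step

The compounds below may be only part of what the source reports. "The series", "measured", "known", "first", "only" and "open" are said of these compounds alone.

Three amides sharing the same fluorinated biaryl aniline have been run in a functional assay on Hep 3B2 cells (Homo sapiens) for antiproliferative activity, read by MTT assay, with a stated time of 24 h, tested at 0.02 ug/mL; a higher number here means a stronger effect of the compound at the concentration tested, a lower number a weaker effect. Compound 1 `Cc1ccc2nc(C(=O)Nc3c(F)cc(-c4cccc(F)c4)cc3F)c(C)c(O)c2c1` gives 0.98%; compound 2 `CCc1ccc2nc(C(=O)Nc3c(F)cc(-c4cccc(F)c4)cc3F)c(C)c(O)c2c1` gives 2.05%; compound 3 `CCOc1ccc2nc(C(=O)Nc3c(F)cc(-c4cccc(F)c4)cc3F)c(C)c(C(=O)O)c2c1` gives 0.05%. The step from compound 2 to compound 1 amounts to a number 1.1 percentage points lower from compound 2 to compound 1 (within the scatter) and is hydrogen in place of methyl on a saturated chain carbon bound to an aromatic carbon. How the core of compound 3 differs from that of compound 2 is not broken down here; the two values of compound 3 and compound 2 lie within the scatter of one another, as do those of compound 3 and compound 1. Compound 4 `COc1ccc2nc(C(=O)Nc3c(F)cc(-c4cccc(F)c4)cc3F)c(C)c(C(=O)O)c2c1` is not yet measured. Its change from compound 3 is hydrogen in place of methyl on a saturated chain carbon bound to an oxygen on an aromatic ring. This is the same kind of change as from compound 2 to compound 1, but the place differs: there the chain carbon is bound to an aromatic carbon, here to an oxygen on an aromatic ring. Because the shown step a number 1.1 percentage points lower from compound 2 to compound 1 (within the scatter) stayed within the scatter, the step from compound 3 to compound 4 is expected to be small, about a number 0.5 percentage points higher from compound 3 to compound 4 (within the scatter). Compound 4 is accordingly estimated at 0.5%, with a range from -3% to 4%.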

Compound 4, a percentage reported as inhibition, at one concentration (the size of the read-out at that concentration, not a potency): -0.57%
Compound 4: the middle estimate sits 1.1 percentage points above what was measured, within the range that was stated.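

In this assay, the change from ethoxy to methoxy on the acid-bearing core gives a number 0.6 percentage points lower from compound 3 to compound 4 (within the scatter). Set beside the change from ethyl to methyl on the other core, this step cannot be told apart from the earlier one: the same change on two cores in this assay, a number 1.1 percentage points lower (within the scatter) from compound 2 to compound 1 and a number 0.6 percentage points lower (within the scatter) from compound 3 to compound 4, 0.5 percentage points apart, within the scatter of two such steps The agreement supports only a limited reading, that on these two cores the loss of the methyl leaves the read-out unmoved beyond the scatter; it does not establish a real effect of the change on either core, nor that the two steps would still match on another core or at another tested concentration.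

Still open, going by these compounds, is whether a longer chain such as propoxy, or an amine in the same place, would move the read-out on the acid-bearing core by more than the scatter. Also open, on these data alone, is whether the agreement between the two steps would hold at a concentration where the read-out is larger.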